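Swapping the Aryl Group on a Shared Core

A few compounds are considered here, and "the series" means these few. Any claim that something is new, unique, unknown or untested is made for them only; others in the source may bear on it.

In a functional assay, with a stated time of 20 min (on this read-out higher numbers stand for weaker inhibition and lower numbers for stronger inhibition), compound 1 `CCOC(=O)c1cnn(-c2nc(-c3ccc(N(C)C)cc3)c(C#N)c(=O)n2C)c1N` gives 98 ug/mL. Compound 2 `CCOC(=O)c1cnn(-c2nc(-c3ccco3)c(C#N)c(=O)n2C)c1N` gives 91 ug/mL in this assay; the two numbers lie within the scatter of each other, so neither stands apart. Among the measured compounds shown here, the only measured step, a 1.1-fold lower number from compound 1 to compound 2 (0.03 log units; within the scatter), varied the group at this same position without moving the read-out beyond the scatter. Compound 3 `CCOC(=O)c1cnn(-c2nc(-c3ccc(Cl)cc3)c(C#N)c(=O)n2C)c1N` differs from compound 2 by 4-chlorophenyl in place of furan-2-yl on an aromatic carbon. Because a 1.1-fold lower number from compound 1 to compound 2 (0.03 log units; within the scatter) showed no shift beyond the scatter, the expected step is a 1.0-fold higher number from compound 2 to compound 3 (0.02 log units; within the scatter), again no change beyond the scatter. Compound 3 is therefore estimated at 95 ug/mL, with a range from 50 ug/mL to 180 ug/mL.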

Compound 3, half-maximal inhibitory concentration: 64 ug/mL
For compound 3 the middle estimate is 1.5-fold (0.17 log units) above the measured one; the range from low to high includes it.
By their numbers in this assay, from the lowest: compounds 3, 2 and 1 (each within the scatter of the next).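

With a chloro-bearing phenyl ring at this position, this assay still shows no shift beyond the scatter (a 1.4-fold lower number from compound 2 to compound 3 (0.15 log units; within the scatter)). Exchanging chloro for dimethylamino on the phenyl ring likewise stays within it (a 1.5-fold lower number from compound 1 to compound 3 (0.19 log units; within the scatter)). The three aromatic groups therefore read alike here, whether a five-membered or a six-membered ring and whichever of these substituents it carries, and nothing available explains this. Still open, from the compounds shown here alone, is whether a non-aromatic group at this position, such as an amine or a longer alkyl chain, would move the number beyond the scatter.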